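Replacing 5-chloro-2-hydroxyphenyl with 4-fluorophenyl on a shared core

The source may hold more compounds than are shown below. What is called first, only, known or untested is meant among the compounds shown, and "the series" means these compounds.

Measured in a functional assay on cells (Erythrocyte, Rattus norvegicus) for inhibition, read by hemolysis, with a stated time of 1 h; a higher number here means a weaker inhibitor, a lower number a stronger inhibitor:
- compound 1 `COc1cc(OC)c(OC)cc1/C=C/C(=O)c1ccc(-c2c[nH]cn2)cc1`: 2.48 ug/mL
- compound 2 `COc1cc(OC)c(OC)cc1/C=C/C(=O)c1ccc(O)cc1O`: 2.37 ug/mL
- compound 3 `COc1cc(OC)c(OC)cc1/C=C/C(=O)c1cc(Cl)ccc1O`: 2.23 ug/mL

At 2.23 ug/mL, compound 3 stands level with the other two, since its gaps to both lie within the scatter of repeated measurements. The next compound is compound 4 `COc1cc(OC)c(OC)cc1/C=C/C(=O)c1ccc(F)cc1`, which has 4-fluorophenyl in place of 5-chloro-2-hydroxyphenyl on a carbonyl carbon.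

For the measured compounds named here, the one measured step at this place is a 1.1-fold lower number from compound 2 to compound 3 (0.03 log units; within the scatter), and it stays within the scatter. Compound 1, with yet another group at this place, gives 2.48 ug/mL, again much the same number. So far, then, changing this group has left the value in this assay essentially unmoved. However, no measured step shows what happens when the group that enters has no hydrogen-bond donor, so the range must stay wide.

The expected step is small, a 1.1-fold higher number from compound 3 to compound 4 (0.03 log units; within the scatter), and none beyond the scatter is predicted. For compound 4 the estimated value is 2.4 ug/mL, with an expected range from 1.2 ug/mL to 4.8 ug/mL.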

Compound 4, half-maximal inhibitory concentration: 2.22 ug/mL
Compound 4: middle estimate off by 1.1-fold (0.03 log units), on the high side; the measured number falls inside the stated range.
By their numbers in this assay, from the lowest: compounds 4, 3, 2 and 1 (each within the scatter of the next).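

With 4-fluorophenyl on the carbonyl carbon, the number in this assay stays level with the other three compounds (a 1.0-fold lower number from compound 3 to compound 4 (0.00 log units; within the scatter); a 1.1-fold lower number from compound 2 to compound 4 (0.03 log units; within the scatter); a 1.1-fold lower number from compound 1 to compound 4 (0.05 log units; within the scatter)). The group that enters has 0 hydrogen-bond donors, whereas each earlier compound kept a donor at this place, so among these four compounds a donor here is not needed to reach this value. No separate measurement is available to explain this flat result.

Going by these compounds, whether an amine, a carboxylic acid or a longer alkyl chain at this place would move the number stays open. The compounds shown also leave open how the number responds to changes elsewhere on the shared core, which is the same in all four.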